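Amine variation on the shared core: isopropyl to benzyl

This account rests on a few compounds, and the source may have more. Where it says the series, first, only, none or still open, it means among the compounds named here.

Compound 1 `CCOC(=O)CNc1oc2c(C)ncc(CO)c2c1Nc1ccccn1`, compound 2 `CCCC(C)Nc1oc2c(C)ncc(CO)c2c1Nc1ccccn1` and compound 3 `Cc1ncc(CO)c2c(Nc3ccccn3)c(NC(C)C)oc12` share one core and differ only in the group on the ring nitrogen. In a functional assay on HEK293 cells for agonist activity at Toll-like receptor 8 (Homo sapiens), read by reporter gene assay (on this read-out higher numbers stand for an effect only at larger amounts of compound and lower numbers for an effect already at smaller amounts), compound 1 is reported as "not active" (no number reported). Compound 3 stands as "not active" (no number reported) in this assay and thus has no number to place it. Among the compounds with values here, compound 2, with a longer alkyl chain at that nitrogen, is the only one with a number, giving 9010 nM in this assay. Compound 4 `Cc1ncc(CO)c2c(Nc3ccccn3)c(NCc3ccccc3)oc12` differs from compound 3 by benzyl in place of isopropyl on a nitrogen on an aromatic ring. Within the data shown here, no measured step covers this change; because compound 2 reaches 9010 nM with a larger group, a gain beyond the scatter over compound 3 is expected for compound 4, though a weak one. Compound 4 is estimated at 5000 nM in this assay, within 1500 nM to 20000 nM, with a real chance that no number results.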

Compound 4, half-maximal effective concentration: 4910 nM
Estimate against measurement, compound 4: 1.0-fold (0.01 log units) above; the measured number falls inside the stated range.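

In this assay, compound 3 with isopropyl stands as "not active" (no number reported), while compound 4 with benzyl gives 4910 nM, so a number at this nitrogen is not confined to an open alkyl chain. Benzyl in place of 1-methylbutyl gives a 1.8-fold lower number from compound 2 to compound 4 (0.26 log units; within the scatter), so these two groups cannot be told apart on this read-out. Compound 2 carries no ring and still gives a number, so the ring of benzyl is not required for one.

On these data alone, whether a phenethyl group, a longer straight alkyl chain or a benzyl bearing a methoxy group would move the number beyond the scatter remains open. No measurement bearing on the reason for these results is available.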